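A few compounds are considered here, and "the series" means these few. Any claim that something is new, unique, unknown or untested is made for them only; others in the source may bear on it.

Measured so far in a functional assay on MCF7 cells (Homo sapiens) for antiproliferative activity, read by MTT assay; on this read-out lower numbers stand for stronger inhibition and higher numbers for weaker inhibition:
- compound 1 `Cc1cccc(Nc2nccc(-c3ccc(Br)cc3)n2)c1`: 210000 nM
- compound 2 `COc1cccc(Nc2nccc(-c3ccc(Cl)c(Cl)c3)n2)c1`: 21000 nM
- compound 3 `Cc1cccc(Nc2nccc(-c3ccc(Cl)cc3Cl)n2)c1`: 249000 nM

Compound 3 (at 249000 nM) sits level with compound 1 within the scatter. Its number lies above that of compound 2 by a gap beyond the scatter.

The next compound is compound 4 `COc1cccc(Nc2nccc(-c3ccc(Cl)cc3Cl)n2)c1`, which carries methoxy in place of methyl on an aromatic carbon, meta to a large group (methoxy in place of methyl on an aromatic carbon). For the measured compounds named here, no measured pair differs in one place only, so this change has no direct precedent. Going by the values given here, the one measured compound with methoxy is compound 2 (at 21000 nM), but it also differs from compound 3 elsewhere, so only part of that gap is expected to carry over.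

The expected change is a moderate move to a lower number, estimated as a 3.6-fold lower number from compound 3 to compound 4 (0.55 log units; beyond the scatter).

For compound 4 the estimate is 70000 nM, with an expected range of 15000 nM to 250000 nM.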

Compound 4, half-maximal inhibitory concentration: 192000 nM
Compound 4: the middle estimate sits 2.7-fold (0.44 log units) below what was measured, and the stated range covers the measured number.
By their numbers in this assay, from the lowest: compound 2; then compounds 4, 1 and 3 (each within the scatter of the next).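

In this assay, methoxy in place of methyl on an aromatic carbon, meta to a large group, gives a 1.3-fold lower number from compound 3 to compound 4 (0.11 log units; within the scatter), so this first direct reading of the change shows no shift beyond the scatter. Compound 2 carries the same methoxy at 21000 nM, while compound 4 gives 192000 nM, so methoxy on its own does not bring the lower number seen for compound 2; that pair differs only in how the two chlorines are placed. No independent data bear on why the number holds here.

Going by these compounds, whether the same swap stays as flat with the bromine of compound 1 remains open, as this is a single pair. Also open, on these data alone, is how an amine, a carboxylic acid or an ethoxy group would read at this position.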